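From 5-Methylthiophen-2-yl to 3-Methylthiophen-2-yl in Compound 1

The compounds below may be only part of what the source reports. "The series", "measured", "known", "first", "only" and "open" are said of these compounds alone.

Values so far in a functional assay on DU-145 cells (Homo sapiens) for inhibition, read by trypan blue exclusion, with a stated time of 96 h (a lower number here means a stronger inhibitor of growth, a higher number a weaker inhibitor of growth), for three compounds:
Compound 1 `Cc1ccc(S(=O)(=O)/C(=C/c2ccc(C)s2)C(=O)c2ccc(Br)cc2)cc1` gives 25000 nM in this series
Compound 2 `Cc1ccc(CS/C(=C/c2c(O)cc(O)cc2O)C(=O)c2ccc(Cl)cc2)cc1` gives 50000 nM in this series
Compound 3 `Cc1ccc(S(=O)(=O)/C(=C/c2ccc(C)s2)C(=O)c2ccc(Cl)cc2)cc1` gives 50000 nM in this series

Compound 1 stands at 25000 nM within the scatter of both other compounds, so these numbers do not set it apart from them. The account now follows compound 4 `Cc1ccc(S(=O)(=O)/C(=C/c2sccc2C)C(=O)c2ccc(Br)cc2)cc1` which has the same atoms as compound 1, joined differently. The difference is 3-methylthiophen-2-yl in place of 5-methylthiophen-2-yl on a double-bonded chain carbon bound to a double-bonded chain carbon and in words it is 3-methylthiophen-2-yl in place of 5-methylthiophen-2-yl on a double-bonded chain carbon bound to a double-bonded chain carbon.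

Among the measured compounds shown here, only one measured step changes a single place, and it is a 2.0-fold higher number from compound 1 to compound 3 (0.30 log units; within the scatter) with chloro in place of bromo on an aromatic carbon. That step lies within the scatter and concerns a different group. For the measured compounds named here, no measured pair shows any change in the methylthiophene group, so the data give no direct guide to this change. In this assay no step beyond the scatter is therefore expected, in either direction. The estimated step is a 1.2-fold higher number from compound 1 to compound 4 (0.08 log units; within the scatter) and it stays within the scatter. For compound 4 the estimated value is 30000 nM with an expected range from 10000 nM to 80000 nM when it is measured.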

Compound 4, concentration for 50% growth inhibition: 25000 nM
For compound 4 the middle estimate is 1.2-fold (0.08 log units) above the measured one; the range from low to high includes it.
By their numbers in this assay, from the lowest: compounds 1, 4, 2 and 3 (each within the scatter of the next).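

In this assay, among the compounds shown here, 3-methylthiophen-2-yl in place of 5-methylthiophen-2-yl on a double-bonded chain carbon bound to a double-bonded chain carbon shows no change at the digits printed from compound 1 to compound 4 (within the scatter), and this is the first step that concerns the methylthiophene group rather than the halogen on the aromatic ring. At this place, then, these two methylthiophene groups, which have the same atoms joined differently, are not told apart by this read-out, and compound 4 falls in with the other three compounds, each within the scatter of the next. No measurement bears on why the two groups read alike, so the result stands without an explanation.

The compounds shown leave open whether this place responds at all to a group that differs from methylthiophene in more than the joining of its atoms, such as a thiophene carrying an amine or a carboxylic acid in place of the methyl. They also leave open whether 3-methylthiophen-2-yl would read the same with chloro in place of bromo on the aromatic carbon, or in any read-out other than this growth measurement.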